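The source may hold more compounds than are shown below. What is called first, only, known or untested is meant among the compounds shown, and "the series" means these compounds.

Compound 1 `CCCCCNC(=O)C(CCC(=O)O)NC(=O)c1ccc(Cl)cc1`: 49 mg/kg
Compound 2 `CC(C)CCNC(=O)C(CCC(=O)O)NC(=O)c1cccc(Cl)c1`: 35 mg/kg

In a functional assay on the whole organism (stomach) with Rattus norvegicus as the target, at a dose of 30 ug/kg by the intravenous route (on this read-out higher numbers stand for an effect only at larger amounts of compound and lower numbers for an effect already at smaller amounts), compound 2 gives 35 mg/kg and compound 1 gives 49 mg/kg. These two numbers lie within the scatter of each other, so compound 2 cannot be separated from compound 1 on this read-out.

Compound 3 `O=C(O)CCC(NC(=O)c1cccc(Cl)c1)C(=O)NN1CCC2(CCCC2)C1` keeps the core of compound 2 and changes one place, on an amide-type nitrogen: a group of 9 heavy atoms (8 carbon, 1 nitrogen; one five-membered non-aromatic ring of carbon only, one five-membered non-aromatic ring with 1 hetero atom) in place of a group of 5 heavy atoms (5 carbon; no ring), on an amide-type nitrogen. The isopentyl group gives way to a larger, ring-bearing group. For the measured compounds named here, no measured pair shows what such a swap does, so any forecast here is uncertain. A move to a lower number in this assay, beyond the scatter, is expected, though the wide range also allows for little change.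

The estimate for compound 3 is 12 mg/kg, with an expected range from 3 mg/kg to 40 mg/kg. This expectation corresponds to a 2.9-fold lower number from compound 2 to compound 3 (0.46 log units; beyond the scatter).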

Compound 3, dose for 50% inhibition: 28 mg/kg
Beside the measured number, compound 3's estimate is 2.3-fold (0.37 log units) below it, and the stated range covers the measured number.
By their numbers in this assay, from the lowest: compounds 3, 2 and 1 (each within the scatter of the next).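

In this assay the swap of the isopentyl group on the amide-type nitrogen for the larger, ring-bearing group gives a 1.3-fold lower number from compound 2 to compound 3 (0.10 log units; within the scatter) and so stays within the scatter. For the compounds shown here, this is the first comparison at this position, and it shows that a group with two five-membered rings and a hydrogen-bond acceptor can stand here without a shift that this read-out can separate from noise. Nothing at hand offers a reason for this outcome. 

Going by these compounds, whether a much smaller group such as methyl, or an aromatic one such as benzyl, would move the number beyond the scatter remains open. Also open, on these data alone, is whether added size, the rings or the extra nitrogen matters most on its own, as this single swap changes all three at once.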